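The source may hold more compounds than are shown below. What is called first, only, known or untested is meant among the compounds shown, and "the series" means these compounds.

Compound 1 `O=C(NO)c1ccc(/C=C/c2ccnc(-c3cc(F)ccc3O)c2)cc1` gives 1920 nM in a functional assay on MGC-803 cells (Homo sapiens) for antiproliferative activity, read by CellTiter-Glo, with a stated time of 72 h (a higher number here means a weaker inhibitor, a lower number a stronger inhibitor), and compound 2 `O=C(NO)c1ccc(/C=C/c2ccnc(-c3cccc(CO)c3)c2)cc1` gives 1740 nM; the two sit within the scatter of each other, as the step of a 1.1-fold lower number from compound 1 to compound 2 (0.04 log units; within the scatter) shows. Compound 3 `O=C(NO)c1ccc(/C=C/c2ccnc(-c3ccc(F)cc3)c2)cc1` reaches only the limit of this assay, > 10000 nM (the limit of > 10000 nM in this assay, at which 1 of the 3 values shown sits). Compound 4 `O=C(NO)c1ccc(/C=C/c2ccnc(-c3ccsc3)c2)cc1` differs from compound 1 in one place: thiophen-3-yl in place of 5-fluoro-2-hydroxyphenyl on an aromatic carbon. The steps of an at least 5.2-fold higher number from compound 1 to compound 3 (0.71 log units; beyond the scatter) and an at least 5.7-fold higher number from compound 2 to compound 3 (0.75 log units; beyond the scatter) are the ones that bear on this change, since in each case a ring carrying a hydroxyl or hydroxymethyl group gave way to one without a hydrogen-bond donor, and the number rose at least modestly. The thiophen-3-yl group likewise carries no donor, so a higher number is expected. Compound 4 is therefore estimated at 6000 nM, between 2000 nM and 20000 nM, an expected step of a 3.1-fold higher number from compound 1 to compound 4 (0.49 log units; beyond the scatter).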

Compound 4, half-maximal inhibitory concentration: 3680 nM
Beside the measured number, compound 4's estimate is 1.6-fold (0.21 log units) above it; low and high end bracket the measured number.
By their numbers in this assay, from the lowest: compounds 2, 1 and 4 (each within the scatter of the next, the first and the last beyond it). At a limit, above all of these: compound 3.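

At this position, next to the ring nitrogen, a ring with 0 hydrogen-bond donors can match one that has a donor: thiophen-3-yl and 5-fluoro-2-hydroxyphenyl cannot be told apart, with a 1.9-fold higher number from compound 1 to compound 4 (0.28 log units; within the scatter). Against 3-(hydroxymethyl)phenyl, thiophen-3-yl does show a cost, a 2.1-fold higher number from compound 2 to compound 4 (0.33 log units; beyond the scatter), but against 4-fluorophenyl it gives an at least 2.7-fold lower number from compound 3 to compound 4 (0.43 log units; beyond the scatter), so lacking a donor does not alone decide the result. The value of compound 3 is a limit: the limit of > 10000 nM in this assay, at which 1 of the 4 values shown sits.

Still open, from the compounds shown here alone, is whether ring size or the sulfur atom separates thiophen-3-yl from 4-fluorophenyl. An amine or a carboxylic acid on the ring at this position also remains untested among the compounds shown.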